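The source may hold more compounds than are shown below. What is called first, only, known or untested is meant among the compounds shown, and "the series" means these compounds.

Compound 1 `Cc1nnc(SCC(=O)c2ccc(Cl)cc2)n1N1C(=O)c2ccccc2C1=O` was found in this study; in a functional assay on HepG2 cells (Homo sapiens) for cytotoxicity, read by MTT assay, with a stated time of 48 h (on this read-out higher numbers stand for weaker inhibition and lower numbers for stronger inhibition), compound 1 gives only a limit of the assay, > 200000 nM.
Compound 2 `C=CCSc1nnc(CC)n1N1C(=O)c2ccccc2C1=O` was found; in this assay compound 2 gives only a limit, > 200000 nM.
Compound 3 `C=CCSc1nnc(CCC)n1N1C(=O)c2ccccc2C1=O` was found; in this assay compound 3 gives only a limit, > 200000 nM.

Compound 3 therefore stands at the limit of what this assay can report, with no number of its own. For the measured compounds named here, the one change among the measured compounds that alters a single place, from compound 2 to compound 3, reads a step that the two limits leave unreadable from compound 2 to compound 3, because both ends sit at the limit of > 200000 nM in this assay, at which 3 of the 3 values shown sit. The step to the unmeasured compound 4 `CCCc1nnc(SCC(=O)c2ccccc2)n1N1C(=O)c2ccccc2C1=O` is a different change: benzoyl in place of vinyl on a saturated chain carbon bound to a sulfur. Going by the values given here, no measured step matches it, so no size can be read for it. Compound 1 also carries a benzoyl-type group on the sulfur-bound chain carbon, and its value shows only a limit as well, without a readable step to compound 3 or compound 4. The expectation for compound 4 is thus a step that the limit leaves unreadable from compound 3 to compound 4, no direction beyond the scatter being readable. Compound 4 is estimated to remain at the limit, around 250000 nM, within 100000 nM to 1000000 nM.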

Compound 4, half-maximal inhibitory concentration: > 200000 nM
Compound 4: a limit, no number; the forecaster's own chance of this, stated with the estimate: 85%; the middle value is on the limit's open side.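

Compound 4 gives only a limit, so no step can be read from compound 3 to compound 4 in this assay, because both ends sit at the same limit: the limit of > 200000 nM in this assay, at which 4 of the 4 values shown sit.

The compounds shown leave open how far any of these changes on the sulfur-bound chain carbon alters cytotoxicity, since none of them has a number of its own.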